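The source may report more compounds than this note shows. Statements on the series, on what has been measured and on what is new or still open speak of the compounds shown alone.

Measured so far:
compound 1 `CCC(OC)C1=C(N2CC2)C(=O)C(C)=C(N2CC2)C1=O` gives 5.33
compound 2 `CC1=C(N2CC2)C(=O)C(COc2ccccc2)=C(N2CC2)C1=O` gives 4.71

Both numbers come from a functional assay on L1210 cells (Mus musculus), with a stated time of 12 days; a higher number here means a more potent compound, by a factor of ten per unit of this negative logarithm, a lower number a less potent compound. Compound 2 stands lowest of the two; compound 1 stands above it by a margin beyond the usual scatter. Among the compounds with values here, the two measured compounds differ from each other in more than one place, so no single measured step is available from which to read the weight of one change.

Compound 3 `CC1=C(N2CC2)C(=O)C(Cc2ccccc2)=C(N2CC2)C1=O` is not yet measured. It differs from compound 2 in one place: phenyl in place of phenoxy on a saturated chain carbon bound to a double-bonded ring carbon. The aziridine-bearing core and the methyl group are unchanged. Within the data shown here, with no measured step to lean on, the expectation in this assay is a step of no meaningful size, estimated at a number 0.19 log units higher from compound 2 to compound 3 (within the scatter), within the scatter. For compound 3 the estimate is 4.9, with a range from 4.3 to 5.5.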

Compound 3, logarithm of the reciprocal of the active concentration, log(1/C): 4.69
Compound 3: middle estimate off by 0.21 log units, on the high side; the measured number falls inside the stated range.
By their numbers in this assay, from the lowest: compounds 3 and 2 (each within the scatter of the next); then compound 1.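

In this assay, phenyl in place of phenoxy on a saturated chain carbon bound to a double-bonded ring carbon gives a number 0.02 log units lower from compound 2 to compound 3 (within the scatter), so this read-out does not tell the two groups apart at this place. Benzyl in place of 1-methoxypropyl on a double-bonded ring carbon gives a number 0.64 log units lower from compound 1 to compound 3 (beyond the scatter), the first single-place step beyond the scatter, which shows that the group at this place can shift the number in this assay. Nothing at hand accounts for either step.

Still open, on these data alone, is whether the standing of compound 1 goes with the methoxy group or with the chain that carries it, which a plain propyl chain on the same ring carbon would help to separate. Also open, as far as these compounds go, is how an amine or a carboxylic acid on the chain carbon would read.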